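The source may hold more compounds than are shown below. What is called first, only, known or untested is meant among the compounds shown, and "the series" means these compounds.

The compounds share one core, seen in compound 2 `Cc1c(C(=O)N/N=C\c2ccccc2)oc2cccc(O)c12`, and differ only in the aryl group on the carbon with a double bond to nitrogen. In a functional assay on PC-3 cells (Homo sapiens) for inhibition (a higher number here means a weaker inhibitor, a lower number a stronger inhibitor), compound 2 gives 29200 nM. Compound 1 `Cc1c(C(=O)N/N=C\c2ccncc2)oc2cccc(O)c12` carries pyridin-4-yl there, and in this assay compound 1 reaches only the limit of the assay, >= 40000 nM, so no number is known for it. Compound 3 `Cc1c(C(=O)N/N=C\c2ccccc2C(F)(F)F)oc2cccc(O)c12` adds a trifluoromethyl group to the phenyl ring and gives 26200 nM in this assay. Of the two numbers shown, compound 2 stands highest, with compound 3 nearest at a 1.1-fold lower number from compound 2 to compound 3 (0.05 log units; within the scatter). The step of an at least 1.3-fold lower number from compound 1 to compound 2 (0.13 log units; that floor lies within the scatter) rests on a limit, namely (the limit of >= 40000 nM in this assay, at which 1 of the 3 values shown sits).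

Compound 4 `Cc1c(C(=O)N/N=C\c2ccc(O)cc2O)oc2cccc(O)c12` changes the same aryl group: 2,4-dihydroxyphenyl in place of phenyl on a carbon with a double bond to nitrogen. Both measured steps touched this aryl group, and neither moved the number beyond the usual scatter. Going by the values given here, the added hydroxyl groups are a different kind of change, and no measured step gives a direction for hydroxyl substitution here. For compound 4 the expected step is a 1.3-fold lower number from compound 2 to compound 4 (0.12 log units; within the scatter) in this assay. The estimate for compound 4 in this assay is 22000 nM, within a range from 9000 nM to 55000 nM.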

Compound 4, half-maximal inhibitory concentration: 14800 nM
The estimate for compound 4 lay 1.5-fold (0.17 log units) above the measured number; low and high end bracket the measured number.
By their numbers in this assay, from the lowest: compounds 4, 3 and 2 (each within the scatter of the next). At a limit, above all of these: compound 1.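

Compound 4 is the first compound shown that places hydroxyl groups on this aryl group, bringing hydrogen-bond donors and acceptors to the position on the carbon with a double bond to nitrogen, where phenyl has none. In this assay, the step is a 2.0-fold lower number from compound 2 to compound 4 (0.30 log units; within the scatter), so this change, like the two steps before it, does not separate the compounds beyond the usual scatter. The new information comes from the comparison with the pyridin-4-yl compound, an at least 2.7-fold lower number from compound 1 to compound 4 (0.43 log units; beyond the scatter), which is the first step at this position printed as beyond the scatter, although compound 1 has only a limit and the size of the step is therefore a floor: the limit of >= 40000 nM in this assay, at which 1 of the 4 values shown sits.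

The compounds shown leave open whether either hydroxyl group alone would give the same reading, and whether a methoxy group or an amine in its place would do so too. They also leave open how the number would respond to a carboxylic acid or a longer chain on the aryl group, and whether any change at this position can move the number beyond the scatter from that of compound 2.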